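Replacing the Dimethylaminobenzyl Group with a Fluorobenzyl Group

The source may hold more compounds than are shown below. What is called first, only, known or untested is meant among the compounds shown, and "the series" means these compounds.

Of the compounds shown here, two have been measured in an assay on CHO cells for displacement of a labelled ligand from prostaglandin E2 receptor EP1 subtype (Homo sapiens); on this read-out lower numbers stand for stronger inhibition and higher numbers for weaker inhibition. Compound 1 `COc1ccc(Cc2nnc(CN(c3cccc(C(F)(F)F)c3C)S(=O)(=O)c3ccc(C)cc3)o2)cc1` gives 63.1 nM in this assay. Compound 2 `Cc1ccc(S(=O)(=O)N(Cc2nnc(Cc3ccc(N(C)C)cc3)o2)c2cccc(Cl)c2C)cc1` gives 12.6 nM in this assay, the lower of the two numbers, and its distance from compound 1 lies beyond the usual scatter. Compounds 1 and 2 differ in more than one place, so the two numbers alone do not tell which part of the structure accounts for the gap.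

Compound 3 `Cc1ccc(S(=O)(=O)N(Cc2nnc(Cc3ccccc3F)o2)c2cccc(Cl)c2C)cc1` has not yet been measured. It differs from compound 2 in one place: 2-fluorophenyl in place of 4-(dimethylamino)phenyl on a saturated chain carbon bound to an aromatic carbon. Within the data shown here, no measured pair shows this single change, so its size is uncertain. The expected step from compound 2 to compound 3 is a moderate shift toward weaker inhibition, a 3.2-fold higher number from compound 2 to compound 3 (0.50 log units; beyond the scatter). Compound 3 is therefore estimated at 40 nM, within a range from 12 nM to 130 nM.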

Compound 3, half-maximal inhibitory concentration: 501 nM
The estimate for compound 3 lay 13-fold (1.10 log units) below the measured number; the measured number lies above the stated range.
By their numbers in this assay, from the lowest: compound 2; then compound 1; then compound 3.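

In this assay, the group on the saturated chain carbon proves to have a strong effect on the number: 2-fluorophenyl in place of 4-(dimethylamino)phenyl gives a 40-fold higher number from compound 2 to compound 3 (1.60 log units; beyond the scatter). Among these compounds, compounds 1 and 2 differ in more than one place, so only this pair isolates a single change, and it shows that this one place alone can produce a large step. No supporting data accompany this result, and the step cannot be assigned to any particular feature of either group.

The compounds shown cannot separate the loss of the dimethylamino group from the arrival of the fluorine, nor from the change in where the ring carries its substituent. A plain phenyl or a 4-fluorophenyl in the same place would help pull these apart.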